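The compounds below may be only part of what the source reports. "The series", "measured", "known", "first", "only" and "open" are said of these compounds alone.

In a functional assay on A549 cells (Homo sapiens) for inhibition, read by MTT assay, with a stated time of 72 h (a lower number here means a stronger inhibitor, a higher number a weaker inhibitor), compound 2 `CN(C(=O)NC(=O)c1ccc(F)c(F)c1)c1nc(C(F)(F)F)c(C(=O)N/N=C/c2ccccc2C(F)(F)F)s1` gives 6.96 ug/mL; compound 1 `CN(C(=O)NC(=O)c1ccc(Cl)cc1Cl)c1nc(C(F)(F)F)c(C(=O)N/N=C/c2cccc(C(F)(F)F)c2)s1` gives 10.6 ug/mL, and the two numbers lie within the usual scatter, so neither can be set above the other. Compound 3 `CN(C(=O)NC(=O)c1ccc(Cl)cc1Cl)c1nc(C(F)(F)F)c(C(=O)N/N=C/c2ccccc2C(F)(F)F)s1` keeps the core of compound 2 and carries 2,4-dichlorophenyl in place of 3,4-difluorophenyl on a carbonyl carbon. Among the compounds with values here, no measured pair shows this exchange on its own, though compound 1, which already carries the 2,4-dichlorophenyl group, reads 10.6 ug/mL. The step of a 1.2-fold higher number from compound 2 to compound 3 (0.09 log units; within the scatter) is therefore expected to stay within the scatter. Compound 3 is estimated at 8.5 ug/mL, with a range from 4 ug/mL to 18 ug/mL.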

Compound 3, half-maximal inhibitory concentration: 15.3 ug/mL
Compound 3: the middle estimate sits 1.8-fold (0.26 log units) below what was measured; low and high end bracket the measured number.
By their numbers in this assay, from the lowest: compounds 2, 1 and 3 (each within the scatter of the next, the first and the last beyond it).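

In this assay the exchange of 3,4-difluorophenyl for 2,4-dichlorophenyl on a carbonyl carbon now stands alone, and a 2.2-fold higher number from compound 2 to compound 3 (0.34 log units; beyond the scatter) shows that this position responds modestly to it when 2-(trifluoromethyl)phenyl is present. The other exchange, 2-(trifluoromethyl)phenyl in place of 3-(trifluoromethyl)phenyl on a carbon with a double bond to nitrogen, reads a 1.4-fold higher number from compound 1 to compound 3 (0.16 log units; within the scatter) and so shows no clear effect. Nothing available explains either step. Still open, as far as these compounds go, is how a plain phenyl, an amine or a carboxylic acid would read at the carbonyl position, and whether the first step holds alongside 3-(trifluoromethyl)phenyl.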